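A few compounds are considered here, and "the series" means these few. Any claim that something is new, unique, unknown or untested is made for them only; others in the source may bear on it.

Among the two compounds measured in a functional assay on the whole organism (strain Swiss albino) for inhibition, with Mus musculus as the target, in the writhing test, with a stated time of 30 min, at a dose of 10 mg/kg by the oral route (a lower number here means a weaker effect, a higher number a stronger effect of the compound at the dose given), compound 2 `Cc1c(C=O)cc(-c2ccc(S(C)(=O)=O)cc2)n1-c1ccc(F)c(F)c1` stands highest with 53%, while compound 1 `Cc1c(C=O)cc(-c2ccc(S(C)(=O)=O)cc2)n1-c1cccc(F)c1` gives 39%. Compound 3 `Cc1c(C=O)cc(-c2ccc(S(C)(=O)=O)cc2)n1-c1ccccc1` differs from compound 2 by phenyl in place of 3,4-difluorophenyl on an aromatic nitrogen. For the measured compounds named here, the only step that bears on this is the one from compound 1 to compound 2, a number 14 percentage points higher from compound 1 to compound 2 (beyond the scatter), where fluoro in place of hydrogen on an aromatic carbon raised the number; compound 3 undoes that and loses the other fluorine as well. A downward step is therefore expected, a number 23 percentage points lower from compound 2 to compound 3 (beyond the scatter), and compound 3 is estimated at 30%, within a range from 12% to 48%.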

Compound 3, a percentage reported as inhibition, in the whole organism at one dose (the size of the read-out at that dose, not a potency): 23%
Compound 3: middle estimate off by 7 percentage points, on the high side; the range from low to high includes it.
By their numbers in this assay, from the lowest: compound 3; then compound 1; then compound 2.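

Against the phenyl of compound 3, the ring on the aromatic nitrogen now has an unsubstituted reference: a number 16 percentage points lower from compound 1 to compound 3 (beyond the scatter) shows that a single fluoro already matters in this assay, and a number 30 percentage points lower from compound 2 to compound 3 (beyond the scatter) shows a larger change with 3,4-difluorophenyl. Among these three compounds, the number rises with each added fluoro, and none goes against this. Nothing available explains this rise.

Going by these compounds, whether a chloro or methoxy group on this ring would act like fluoro remains open. So does whether the order would hold at other doses.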